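The source may report more compounds than this note shows. Statements on the series, on what has been measured and on what is new or still open speak of the compounds shown alone.

Compound 1 (`CCCCOC(=O)c1cc(CC)sc1NC(=O)c1ccc([N+](=O)[O-])o1`) was tested in an ADME assay on HeLa cells (Homo sapiens) for cytotoxicity, read by resazurin assay, with a stated time of 65 h (on this read-out higher numbers stand for an effect only at larger amounts of compound and lower numbers for an effect already at smaller amounts), and there compound 1 gives > 20000 nM as a limit, not as a number. Compound 2 (`CCc1cc(C(N)=O)c(NC(=O)c2ccc([N+](=O)[O-])o2)s1`) gives > 20000 nM in this assay as a limit too. Compound 1 therefore has no exact number to stand on, and the whole picture so far is the limit of > 20000 nM in this assay, at which 2 of the 2 values shown sit, and nothing more.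

The change to compound 3 (`CCc1cc(C(=O)NCCO)c(NC(=O)c2ccc([N+](=O)[O-])o2)s1`) is (2-hydroxyethyl)amino in place of butoxy on a carbonyl carbon and reads, in words, (2-hydroxyethyl)amino in place of butoxy on a carbonyl carbon. The nearest measured change is a step that the two limits leave unreadable from compound 1 to compound 2 with amino in place of butoxy on that carbonyl carbon, and it supplies no size that could be carried over. No step beyond the scatter is therefore expected in this assay, and no direction can be given. The estimated change is a step that the limit leaves unreadable from compound 1 to compound 3 in this expectation. For compound 3 the estimated value is 25000 nM within an expected range of 10000 nM to 50000 nM and the assay may well report only a limit again.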

Compound 3, half-maximal effective concentration: > 20000 nM
Compound 3: no number, only a limit; the forecaster's own chance of this, stated with the estimate: 85%; the middle value is on the limit's open side.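

In this assay compound 3 also gives only a limit, so no step among compound 1, compound 2 and compound 3 can be read: the limit of > 20000 nM in this assay, at which 3 of the 3 values shown sit.

The compounds shown leave open at what concentration any of them would register in this assay, and whether butoxy, amino or (2-hydroxyethyl)amino on the carbonyl carbon changes that concentration at all.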